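A few compounds are considered here, and "the series" means these few. Any claim that something is new, unique, unknown or untested is made for them only; others in the source may bear on it.

Measured compounds:
compound 1, `Cc1n[nH]c(C(=O)O)c1Cc1ccc2ccccc2n1`, giving 2% in an assay on isolated protein for inhibition of 2-Hydroxyacid oxidase 2 (Homo sapiens), tested at 1 uM; on this read-out lower numbers stand for a weaker effect and higher numbers for a stronger effect at the one concentration tested
compound 2, `Cc1n[nH]c(C(=O)O)c1Cc1cccc(-c2cccc(F)c2)c1`, giving 20% in this assay

Of the two numbers shown, compound 2 stands highest, and its nearest neighbour is compound 1, whose value lies lower by an amount beyond the usual scatter. The step from compound 2 leads to compound 3, `Cc1n[nH]c(C(=O)O)c1Cc1cccc(C(F)(F)F)c1`, which has not yet been measured in this assay. The change is trifluoromethyl in place of 3-fluorophenyl on an aromatic carbon. Going by the values given here, no step between two measured compounds of the same kind exists to guide this change, so any expectation rests only on the two values given and on the fact that a group of seven heavy atoms with one ring leaves and a group of four heavy atoms without a ring enters. A step downward, beyond the scatter, is expected for compound 3, as a number 12 percentage points lower from compound 2 to compound 3 (beyond the scatter). In this assay compound 3 is therefore estimated at 8%, with a range from 0% to 22%.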

Compound 3, a percentage reported as inhibition, at one concentration (the size of the read-out at that concentration, not a potency): 5%
Estimate against measurement, compound 3: 3 percentage points above, within the range that was stated.
By their numbers in this assay, from the lowest: compounds 1 and 3 (each within the scatter of the next); then compound 2.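

In this assay, going by these compounds alone, the exchange of 3-fluorophenyl for trifluoromethyl on an aromatic carbon gives a number 15 percentage points lower from compound 2 to compound 3 (beyond the scatter) as the first direct reading of a change at this position. With the rest of the structure held constant, the read-out at this position therefore depends on the group it carries, and here the pair's higher value goes with the ring-bearing 3-fluorophenyl group. Nothing at hand accounts for this modest step.

The compounds shown leave open whether the ring or its fluorine matters more, as plain phenyl does not appear among them. Also open, going by these compounds, is how this assay would respond to an amine, a methoxy group or a longer alkyl chain on the same aromatic carbon.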